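Hydroxy to methyl on compound 3

The source may hold more compounds than are shown below. What is called first, only, known or untested is meant among the compounds shown, and "the series" means these compounds.

Compound 3 (`CSc1ccc(C2=C(c3ccc(O)cc3)C(=O)N3CCCC3C2)cc1`) stands at > 100000 nM in a functional assay on DU-145 cells (Homo sapiens) for cytotoxicity (on this read-out higher numbers stand for weaker inhibition of growth and lower numbers for stronger inhibition of growth), and that value is a limit, not a number. In this assay compound 1 (`COc1ccc(C2=C(c3ccc(SC)cc3)CC3CCCN3C2=O)cc1Br`) gives 900 nM and compound 2 (`CSc1ccc(C2=C(c3ccc(F)c(F)c3)C(=O)N3CCCC3C2)cc1`) gives 500 nM and these lie within the scatter of each other (a 1.8-fold lower number from compound 1 to compound 2 (0.26 log units; within the scatter)). Compound 4 (`CSc1ccc(C2=C(c3ccc(C)cc3)C(=O)N3CCCC3C2)cc1`) has methyl in place of hydroxy on an aromatic carbon and so carries 4-methylphenyl. Two large steps bear on this, both ending at the 4-hydroxyphenyl group of compound 3 (an at least 110-fold higher number from compound 1 to compound 3 (2.04 log units; beyond the scatter); an at least 200-fold higher number from compound 2 to compound 3 (2.30 log units; beyond the scatter)). Their reverse suggests a large move to a lower number, so the expected step is an at least 120-fold lower number from compound 3 to compound 4 (2.09 log units; beyond the scatter) and it lies beyond the scatter. The estimated value for compound 4 is 800 nM (range 200 nM to 5000 nM).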

Compound 4, concentration for 50% growth inhibition: 600 nM
Compound 4: the middle estimate sits 1.3-fold (0.12 log units) above what was measured; measured number inside the range.
By their numbers in this assay, from the lowest: compounds 2, 4 and 1 (each within the scatter of the next). At a limit, above all of these: compound 3.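

In this assay, the change from hydroxy to methyl on an otherwise unchanged 4-substituted phenyl ring gives an at least 160-fold lower number from compound 3 to compound 4 (2.22 log units; beyond the scatter), so the earlier large steps, which also changed other substituents, can now be traced to this one swap. The 4-methylphenyl group needs neither halogen nor methoxy to match the other two compounds, with a 1.2-fold higher number from compound 2 to compound 4 (0.08 log units; within the scatter) and a 1.5-fold lower number from compound 1 to compound 4 (0.18 log units; within the scatter). Compound 3 stands at a limit, not a number: the limit of > 100000 nM in this assay, at which 1 of the 4 values shown sits.

Going by these compounds, whether an amine or a carboxylic acid at this place would behave like hydroxy or like methyl remains open. So does the outcome for an ethyl group or a longer chain there.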